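Removing a benzyloxycarbonyl cap from a piperazine-bearing triazole

The source may hold more compounds than are shown below. What is called first, only, known or untested is meant among the compounds shown, and "the series" means these compounds.

Four compounds share a core in which a substituted benzyl group hangs from a triazole, which in turn carries a dithiocarbamate linked to a piperazine. Compound 1 `COc1ccc(Cn2cc(CSC(=S)N3CCNCC3)nn2)cc1` carries a methoxy on the benzyl ring and a free piperazine nitrogen; in a functional assay on MGC-803 cells (Homo sapiens) for inhibition, read by MTT assay, with a stated time of 72 h (on this read-out lower numbers stand for stronger inhibition and higher numbers for weaker inhibition), compound 1 was "not determined" (no result reported). Compound 2 `Fc1ccc(Cn2cc(CSC(=S)N3CCNCC3)nn2)cc1` is the fluoro analogue with the same free piperazine; in this assay compound 2 gives 32500 nM. Going by the values given here, compound 3 `Cc1ccc(Cn2cc(CSC(=S)N3CCN(C(=O)OCc4ccccc4)CC3)nn2)cc1` carries a methyl on the benzyl ring and a benzyloxycarbonyl on the piperazine nitrogen; in this assay compound 3 gives 9370 nM, the lowest of the two numbers measured so far, with compound 2 the nearest and beyond the scatter above it.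

Compound 4 `Cc1ccc(Cn2cc(CSC(=S)N3CCNCC3)nn2)cc1` is the unmeasured target. The change from compound 3 is hydrogen in place of benzyloxycarbonyl on an amine nitrogen in a ring. Among the compounds with values here, no measured pair isolates this exact change, but compound 2, which also has a free piperazine nitrogen, gives 32500 nM in this assay, a weaker result than compound 3. The step from compound 3 to compound 4 is therefore expected to go toward weaker inhibition, by a 3.0-fold higher number from compound 3 to compound 4 (0.48 log units; beyond the scatter), beyond the scatter. For compound 4 an inhibitory concentration of 28000 nM is estimated, within 10000 nM to 70000 nM, because compound 2 gives 32500 nM with the same free nitrogen.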

Compound 4, half-maximal inhibitory concentration: 64300 nM
Beside the measured number, compound 4's estimate is 2.3-fold (0.36 log units) below it, and the stated range covers the measured number.
By their numbers in this assay, from the lowest: compound 3; then compounds 2 and 4 (each within the scatter of the next).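

In this assay, compound 3 and compound 4 differ in one place only, so a 6.9-fold higher number from compound 3 to compound 4 (0.84 log units; beyond the scatter) isolates the change of benzyloxycarbonyl to hydrogen on the amine nitrogen in the ring and shows that, with the methyl on the benzyl ring held constant, the capped nitrogen goes with stronger inhibition; the earlier comparison of compound 2 with compound 3 could not show this, as those two differ in two places. The second comparison, methyl in place of fluoro on an aromatic carbon, gives a 2.0-fold higher number from compound 2 to compound 4 (0.30 log units; within the scatter) and lies within the scatter, so compound 2 and compound 4 cannot be told apart in this assay, and the two free-nitrogen compounds read as one level of inhibition. Nothing given here offers a measured reason for the difference that comes with the cap.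

As far as these compounds go, it remains open whether the whole benzyloxycarbonyl group is needed or whether a smaller acetyl group or a plain benzyl group on the same nitrogen would keep the stronger inhibition. From the compounds shown here alone, whether the cap has a similar effect with fluoro on the benzyl ring also stays open, and compound 1, with no reported result, adds nothing on methoxy.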